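This account rests on a few compounds, and the source may have more. Where it says the series, first, only, none or still open, it means among the compounds named here.

Compound 1 `COc1ccc2c(=O)c(/C=C/C(=O)Nc3cc(C)ccc3C)coc2c1` gives the highest of the two numbers available in a functional assay on HeLa cells (Homo sapiens) for inhibition, read by MTT assay, with a stated time of 48 h (a higher number here means a weaker inhibitor, a lower number a stronger inhibitor), at 58400 nM. Compound 2 `Cc1ccccc1NC(=O)/C=C/c1coc2cc(O)ccc2c1=O` gives 8670 nM in this assay, a lower number than compound 1, and the gap between the two lies beyond the scatter. Compound 3 `Cc1ccc(CNC(=O)/C=C/c2coc3cc(O)ccc3c2=O)cc1` gives only a limit of the assay, > 100000 nM, in this assay; this is the limit of > 100000 nM in this assay, at which 1 of the 3 values shown sits. Among the measured compounds shown here, the one step measured, an at least 11-fold higher number from compound 2 to compound 3 (1.06 log units; beyond the scatter), concerns an exchange of an aryl amide for a benzyl amide on the hydroxy-bearing core and so does not directly bear on an aryl-to-aryl exchange.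

Compound 4 `COc1ccc2c(=O)c(/C=C/C(=O)Nc3ccc(F)cc3)coc2c1` is compound 1 with 4-fluorophenyl in place of 2,5-dimethylphenyl on an amide-type nitrogen. For the measured compounds named here, no measured step maps onto this change: the amide-type nitrogen keeps a six-membered aromatic ring of carbon only, and only the substituents on that ring differ. The expectation is therefore a step of a 1.5-fold lower number from compound 1 to compound 4 (0.16 log units; within the scatter) in this assay, with no firm direction. Compound 4 is estimated at 40000 nM in this assay, within 10000 nM to 100000 nM.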

Compound 4, half-maximal inhibitory concentration: 9680 nM
Beside the measured number, compound 4's estimate is 4.1-fold (0.62 log units) above it; measured number below the stated range.
By their numbers in this assay, from the lowest: compounds 2 and 4 (each within the scatter of the next); then compound 1. At a limit, above all of these: compound 3.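

In this assay, 4-fluorophenyl in place of 2,5-dimethylphenyl on an amide-type nitrogen gives a 6.0-fold lower number from compound 1 to compound 4 (0.78 log units; beyond the scatter) on the core of compound 1. The earlier step covered only a benzyl-for-aryl exchange on the hydroxy-bearing core, whereas this one shows that changing the substituents alone, with the six-membered aromatic ring of carbon only kept, moves the number beyond the scatter. The exchange removes two methyl groups and adds one fluorine in a single step, so the shift cannot be assigned to either part alone.

No measurement shown gives a reason for this step. Still open, going by these compounds, are how unsubstituted phenyl, 4-chlorophenyl or a ring carrying an amine would read on this nitrogen, and whether 4-fluorophenyl gives a step of similar size on the hydroxy-bearing core.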